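Methoxy for Fluoro: Expecting a Fourth Compound

This account rests on a few compounds, and the source may have more. Where it says the series, first, only, none or still open, it means among the compounds named here.

Measured so far, in a functional assay on HT-29 cells (Homo sapiens) for cytotoxicity, read by MTT assay, with a stated time of 72 h; a higher number here means a weaker inhibitor of growth, a lower number a stronger inhibitor of growth:
compound 1 `N#C[Se]c1ccc(NC(=O)OCc2ccc([N+](=O)[O-])cc2)cc1` gives 47100 nM
compound 2 `N#C[Se]c1ccc(NC(=O)Oc2ccc(F)cc2)cc1` gives 37600 nM
compound 3 `CCCOC(=O)Nc1ccc([Se]C#N)cc1` gives 51900 nM

Compound 2 sits at the low end of these three numbers, yet neither compound 1 nor compound 3 is separated from it by more than the usual scatter, so the three read as one level. Compound 4 `COc1ccc(OC(=O)Nc2ccc([Se]C#N)cc2)cc1` has not yet been measured. It differs from compound 2 by methoxy in place of fluoro on an aromatic carbon. Among the measured compounds shown here, no measured pair shows such a change, and the three measured compounds give no sign of a step of any size from this kind of substitution. Compound 4 is therefore expected to land near compound 2, with a step of a 1.1-fold higher number from compound 2 to compound 4 (0.03 log units; within the scatter) of no more than the scatter in either direction. The estimate for compound 4 is 40000 nM, within 15000 nM to 100000 nM.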

Compound 4, concentration for total growth inhibition: 41500 nM
Estimate against measurement, compound 4: 1.0-fold (0.02 log units) below, and the stated range covers the measured number.
By their numbers in this assay, from the lowest: compounds 2, 4, 1 and 3 (each within the scatter of the next).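

Among the compounds shown here, the swap of fluoro for methoxy, on an aromatic carbon para to a large group, gives the first direct reading of this position: in this assay it produces a 1.1-fold higher number from compound 2 to compound 4 (0.04 log units; within the scatter). At this position, then, the larger methoxy, which carries a hydrogen-bond acceptor, leaves the level of the series intact. No available evidence bears on why the two compounds read alike.

Going by these compounds, whether an amine, a carboxylic acid or a longer chain at this position would hold the same level remains open. A single pair cannot show how far this tolerance extends.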